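Benzothiazole imine series: ester to methylsulfonyl chain

A few compounds are considered here, and "the series" means these few. Any claim that something is new, unique, unknown or untested is made for them only; others in the source may bear on it.

Measured so far:
compound 1 `CC(C)(C)Cc1ccc2nc(N)sc2c1` — > 10 mg/kg
compound 2 `COC(=O)Cn1c(=N)sc2cc(OC(F)(F)F)ccc21` — > 10 mg/kg

In a functional assay on the whole organism with Rattus norvegicus as the target (a lower number here means that less compound is needed, a higher number that more compound is needed for the effect), compound 1 gives only a limit, > 10 mg/kg. In this assay compound 2 likewise gives only a limit, > 10 mg/kg. Among the measured compounds shown here, both measured values thus sit at the limit of > 10 mg/kg in this assay, at which 2 of the 2 values shown sit, and no step between measured compounds can be read from them; compound 2 stands at the limit with nothing finer known.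

Compound 3 `CS(=O)(=O)CCCn1c(=N)sc2cc(OC(F)(F)F)ccc21` is not yet measured. It differs from compound 2 in one place: 2-(methylsulfonyl)ethyl in place of methoxycarbonyl on a saturated chain carbon bound to an aromatic nitrogen. For the measured compounds named here, with both measured values at the limit there is no observed step to lean on, and no direction is expected for the change from compound 2 to compound 3 beyond the scatter. Compound 3 is therefore expected to give about 15 mg/kg, in the range 5 mg/kg to 50 mg/kg, which corresponds to an estimated step that the limit leaves unreadable from compound 2 to compound 3; a result reported only as a limit is considered the more likely outcome for compound 3.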

Compound 3, dose for half-maximal effect: 5 mg/kg
Compound 3: middle estimate off by 3.0-fold (0.48 log units), on the high side; low and high end bracket the measured number.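

In this assay, among the compounds shown here, compound 3 gives 5 mg/kg, the first value that is a number rather than a limit. Replacing methoxycarbonyl with 2-(methylsulfonyl)ethyl on a saturated chain carbon bound to an aromatic nitrogen gives an at least 2.0-fold lower number from compound 2 to compound 3 (0.30 log units; that floor lies within the scatter). The full size of this step cannot be read, because compound 2 gives only a limit: the limit of > 10 mg/kg in this assay, at which 2 of the 3 values shown sit.

The change alters the chain length and the end group together, as its other reading, (methoxycarbonyl)methyl to 3-(methylsulfonyl)propyl, shows, so the compounds shown do not separate the contribution of either. From the compounds shown here alone, a methyl ester carried on a longer chain, or a shorter chain ending in a methylsulfonyl group, would address that question, and how a carboxylic acid or an amine at the chain end would read remains open.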